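Swapping Dichlorophenyl for Dimethoxyphenyl on Compound 1

A few compounds are considered here, and "the series" means these few. Any claim that something is new, unique, unknown or untested is made for them only; others in the source may bear on it.

Compound 1 `Nc1cc(N)c2nc(-c3ccccc3)c(NCc3ccc(Cl)c(Cl)c3)nc2c1` is the strongest growth inhibitor among the three compounds measured in a functional assay on SW-620 cells (Homo sapiens) for inhibition, read by sulforhodamine B assay, with a stated time of 48 h (a higher number here means a weaker inhibitor of growth, a lower number a stronger inhibitor of growth), where compound 1 gives 3240 nM. Compound 2 `Nc1cc(N)c2nc(-c3ccccc3)c(Oc3ccc(F)cc3)nc2c1` gives 19500 nM in this assay, and compound 3 `CCOC(=O)[C@H](CCC(=O)O)NC(=O)c1ccc(Oc2nc3cc(N)cc(N)c3nc2-c2ccccc2)cc1` gives 29500 nM; the steps from compound 1 to each of them lie beyond the scatter. Compound 4 `COc1ccc(CNc2nc3cc(N)cc(N)c3nc2-c2ccccc2)cc1OC` has not yet been measured. It differs from compound 1 in a single place: 3,4-dimethoxyphenyl in place of 3,4-dichlorophenyl on a saturated chain carbon bound to a nitrogen on an aromatic ring. Among the measured compounds shown here, no measured pair shows this exchange, so its effect is unknown. The step of a 1.7-fold higher number from compound 1 to compound 4 (0.23 log units; within the scatter) that this estimate implies is expected to be a modest weakening of growth inhibition, perhaps not beyond the scatter. Compound 4 is therefore estimated at 5500 nM, with a range from 2000 nM to 16000 nM.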

Compound 4, concentration for 50% growth inhibition: 5250 nM
Compound 4: the middle estimate sits 1.0-fold (0.02 log units) above what was measured; measured number inside the range.
By their numbers in this assay, from the lowest: compounds 1 and 4 (each within the scatter of the next); then compounds 2 and 3 (each within the scatter of the next).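

At this place, on a saturated chain carbon bound to a nitrogen on an aromatic ring, 3,4-dimethoxyphenyl in place of 3,4-dichlorophenyl gives a 1.6-fold higher number from compound 1 to compound 4 (0.21 log units; within the scatter) in this assay. This exchange of the two chlorine atoms for two methoxy groups therefore leaves the number within the scatter. No measurement at hand bears on why the two compounds read alike. From the compounds shown here alone, whether an amine or a hydroxyl on this ring, or a longer chain carrying it, would also stay within the scatter of compound 1 remains open.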